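The source may hold more compounds than are shown below. What is called first, only, known or untested is meant among the compounds shown, and "the series" means these compounds.

Measured so far:
- compound 1 `CCCCCCNC(=O)[C@H]1OC(n2cnc3c(N)ncnc32)[C@H](O)[C@@H]1O` — 19 nM
- compound 2 `CCCCCCCCCNC(=O)[C@H]1OC(n2cnc3c(N)ncnc32)[C@H](O)[C@@H]1O` — 31 nM
- compound 3 `CCCCCCCCCCCNC(=O)[C@H]1OC(n2cnc3c(N)ncnc32)[C@H](O)[C@@H]1O` — 123 nM

In an assay on cell membranes for binding affinity to 2-oxoglutarate receptor 1 (Rattus norvegicus), read by radioligand binding (a lower number here means a stronger inhibitor, a higher number a weaker inhibitor), compound 3 gives the highest number of the three measured compounds, so it is the weakest of them; the step of a 4.0-fold higher number from compound 2 to compound 3 (0.60 log units; beyond the scatter) and the step of a 6.5-fold higher number from compound 1 to compound 3 (0.81 log units; beyond the scatter) both lie beyond the scatter, while the step of a 1.6-fold higher number from compound 1 to compound 2 (0.21 log units; within the scatter) does not. The three compounds differ only in how long the straight chain on the amide-type nitrogen is.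

Compound 4 `NCCCCCCCCNC(=O)[C@H]1OC(n2cnc3c(N)ncnc32)[C@H](O)[C@@H]1O` has not yet been measured. Its change from compound 3 is amino in place of propyl on a saturated chain carbon, eight bonds along the chain from an amide-type nitrogen. The chain thus becomes as long, in heavy atoms, as that of compound 2, but it now ends in an amino group rather than a plain carbon.

The measured steps say something about the shortening: the step of a 4.0-fold higher number from compound 2 to compound 3 (0.60 log units; beyond the scatter) went to a weaker binder when the chain grew, so cutting it back should run the other way, towards the value of compound 2. Among the measured compounds shown here, none of the measured compounds carries an amino group at the chain end, so that part of the change is untested here.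

Compound 4 is therefore expected to bind more strongly than compound 3, with an estimated step of a 2.1-fold lower number from compound 3 to compound 4 (0.31 log units; beyond the scatter) in this assay. For compound 4 the estimate in this assay is 60 nM, with a range from 15 nM to 300 nM.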

Compound 4, inhibition constant: 29 nM
Compound 4: middle estimate off by 2.1-fold (0.32 log units), on the high side; the measured number falls inside the stated range.
By their numbers in this assay, from the lowest: compounds 1, 4 and 2 (each within the scatter of the next); then compound 3.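

In this assay, among the compounds shown here, an amino group on a saturated chain carbon, eight bonds along the chain from an amide-type nitrogen, is tolerated, which the all-carbon chains of the earlier compounds could not show. Set against the longest chain, amino in place of propyl gives a 4.2-fold lower number from compound 3 to compound 4 (0.63 log units; beyond the scatter), but this change shortens the chain as well as bringing in the nitrogen, so this step alone cannot separate the two. The cleaner comparison keeps the chain length in heavy atoms the same, amino in place of methyl, and gives a 1.1-fold lower number from compound 2 to compound 4 (0.03 log units; within the scatter), while the comparison with the hexyl chain gives a 1.5-fold higher number from compound 1 to compound 4 (0.18 log units; within the scatter); both lie within the scatter, so these numbers show no difference between the amino-bearing chain and either plain chain.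

Nothing measured here explains this tolerance of the amino group. The compounds shown leave open whether a carboxylic acid or a hydroxyl group on the same chain carbon would be tolerated equally, and whether an amine on a chain as long as that of compound 3 would bring the number down towards that of compound 4.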